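The source may hold more compounds than are shown below. What is called first, only, known or untested is meant among the compounds shown, and "the series" means these compounds.

Measured compounds in a functional assay on J774 cells (Mus musculus) for cytotoxicity, read by resazurin assay, with a stated time of 72 h; on this read-out lower numbers stand for stronger inhibition and higher numbers for weaker inhibition:
compound 1, `O=S(=O)(Nc1cccc(CO)c1)c1ccc(-c2ccc(F)cc2)cc1`, gives 3500 nM;
compound 2, `Cc1ccc(-c2ccc(S(=O)(=O)Nc3cccc(CO)c3)cc2)cc1`, gives 1200 nM.

For the measured compounds named here, compound 2 stands lowest of the two numbers so far; its only neighbour is compound 1, and the step between them is a 2.9-fold lower number from compound 1 to compound 2 (0.46 log units; beyond the scatter). Compound 3, `O=S(=O)(Nc1cccc(CO)c1)c1ccc(-c2ccc(F)cc2F)cc1`, is not yet measured in this assay. It differs from compound 2 by 2,4-difluorophenyl in place of 4-methylphenyl on an aromatic carbon. Going by the values given here, the one measured step that bears on this change is a 2.9-fold lower number from compound 1 to compound 2 (0.46 log units; beyond the scatter), where methyl replaced fluoro on an aromatic carbon and the number fell modestly. Compound 3 reverses that exchange and brings in a second fluoro, so the expected direction is back toward compound 1, a modest rise in the number rather than a fall. The expected step is a 2.5-fold higher number from compound 2 to compound 3 (0.40 log units; beyond the scatter). Compound 3 is therefore estimated at 3000 nM, with a range of 1200 nM to 7500 nM.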

Compound 3, half-maximal inhibitory concentration: 300 nM
Beside the measured number, compound 3's estimate is 10-fold (1.00 log units) above it; the whole stated range lies above it.
By their numbers in this assay, from the lowest: compound 3; then compound 2; then compound 1.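

In this assay, fluoro in place of hydrogen on an aromatic carbon gives a 12-fold lower number from compound 1 to compound 3 (1.07 log units; beyond the scatter), a large step, whereas the earlier exchange of fluoro for methyl gave only a modest one. The 2,4-difluorophenyl group also gives a lower number than 4-methylphenyl, with a 4.0-fold lower number from compound 2 to compound 3 (0.60 log units; beyond the scatter), so the order seen earlier, with methyl ahead of a single fluoro, does not hold once the second fluoro is present. Nothing available explains why the added fluoro has this effect.

The compounds shown leave open whether this drop is particular to fluoro or would also follow with chloro, methoxy or a nitrile on the same ring. They also leave open how the numbers would move if a carboxylic acid or an amine took the place of the hydroxymethyl group on the shared core.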